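A few compounds are considered here, and "the series" means these few. Any claim that something is new, unique, unknown or untested is made for them only; others in the source may bear on it.

Working notes on the step to compound 4 `COc1ccc(CNc2ncnc3c2ncn3C2CCCO2)cc1` in this series. In an ADME assay on BJ cells (Homo sapiens) for cytotoxicity, read by MTT assay, with a stated time of 72 h (on this read-out lower numbers stand for stronger inhibition and higher numbers for weaker inhibition), compound 3 `COc1ccccc1CNc1ncnc2c1ncn2C1CCCO1` gives > 100000 nM as a limit and not a number. Compound 2 `Oc1ccccc1CNc1ncnc2c1ncn2C1CCCO1` gives > 100000 nM as a limit too. Compound 1 `COc1ccc(CNc2ncnc3c2ncn3C2CCCCO2)cc1`, which carries the 4-methoxyphenyl group on a different core, gives > 100000 nM as a limit as well. Compound 3 therefore has only a limit to its name, and the whole series stands at the limit of > 100000 nM in this assay, at which 3 of the 3 values shown sit, with no number yet.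

The change under study is 4-methoxyphenyl in place of 2-methoxyphenyl on a saturated chain carbon bound to a nitrogen on an aromatic ring and leaves the atoms the same, joined differently. Among the compounds with values here, the one measured step, a step that the two limits leave unreadable from compound 2 to compound 3, is a different change and gives no size to carry over. No step beyond the scatter is therefore expected, and the estimated move is a number no higher from compound 3 to compound 4 (the limit leaves the size open) in size. For compound 4 the expected value is 100000 nM with an estimated range of 50000 nM to 200000 nM and a report as a limit is the likeliest outcome.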

Compound 4, half-maximal inhibitory concentration: > 100000 nM
Compound 4: only a limit was reported; the forecaster's own chance of this, stated with the estimate: 90%; the middle value lies on the limit itself.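

In this assay compound 4 gives > 100000 nM, a limit and not a number, so its steps from compound 1, compound 2 and compound 3 cannot be read. The compounds shown leave open what size, if any, these changes have on this read-out, as the series offers only one limit: the limit of > 100000 nM in this assay, at which 4 of the 4 values shown sit.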